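The source may report more compounds than this note shows. Statements on the series, on what has been measured and on what is new or still open speak of the compounds shown alone.

Measured in a functional assay on HepG2 cells (Homo sapiens) for cytotoxicity, read by MTT assay, with a stated time of 24 h; a lower number here means a stronger inhibitor, a higher number a weaker inhibitor:

Compound 1 `COc1cc(/C=C2\CN(S(=O)(=O)c3ccc(F)cc3)C/C(=C\c3cc(OC)cc(OC)c3)C2=O)cc(OC)c1`: 8100 nM
Compound 2 `COc1cc(/C=C2\CN(S(=O)(=O)c3ccc(F)cc3)C/C(=C\c3ccccc3F)C2=O)cc(OC)c1OC`: 7940 nM

Compound 2, at 7940 nM, stands level with compound 1, since their two numbers lie within the scatter of repeated measurements. These two compounds differ in more than one place, so their pair does not isolate any single change.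

The next compound is compound 3 `COc1cc(/C=C2\CN(S(=O)(=O)c3ccc(F)cc3)C/C(=C\c3ccccc3F)C2=O)cc(OC)c1`, still to be measured in this assay. Its structure departs from compound 2 in one place: hydrogen in place of methoxy on an aromatic carbon. In words, hydrogen takes the place of methoxy on an aromatic carbon, so that 3,4,5-trimethoxyphenyl becomes 3,5-dimethoxyphenyl.

Among the measured compounds shown here, no measured pair shows this change on its own, so any forecast is tentative. Compound 1 also carries a 3,5-dimethoxyphenyl group and gives 8100 nM, which offers no sign of a large shift. A step no larger than the scatter is therefore expected, with no firm direction. The estimated step is a 1.1-fold higher number from compound 2 to compound 3 (0.03 log units; within the scatter). For compound 3 the estimated value is 8500 nM, with an expected range from 3500 nM to 20000 nM.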

Compound 3, half-maximal inhibitory concentration: 9300 nM
Estimate against measurement, compound 3: 1.1-fold (0.04 log units) below; the measured number falls inside the stated range.
By their numbers in this assay, from the lowest: compounds 2, 1 and 3 (each within the scatter of the next).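

In this assay, putting hydrogen in place of the methoxy that lies para to a large group and ortho to two methoxy groups turns 3,4,5-trimethoxyphenyl into 3,5-dimethoxyphenyl and gives a 1.2-fold higher number from compound 2 to compound 3 (0.07 log units; within the scatter), so this single edit, now seen on its own, leaves the two compounds level. With the 3,5-dimethoxyphenyl group kept on one side of the shared core, 2-fluorophenyl in place of 3,5-dimethoxyphenyl on the other side gives a 1.1-fold higher number from compound 1 to compound 3 (0.06 log units; within the scatter), so that exchange also leaves the two compounds level. Nothing in the available data accounts for either result.

From the compounds shown here alone, at this position, only methoxy and hydrogen can be compared, so it remains open whether an amine, a carboxylic acid or a longer chain there would move the number beyond the scatter. Going by these compounds, it also remains open whether removing this methoxy would give the same result with a group other than 2-fluorophenyl on the far side of the core.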